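Aryl ether to aryl thioether on the shared core

The compounds below may be only part of what the source reports. "The series", "measured", "known", "first", "only" and "open" are said of these compounds alone.

Measured so far:
compound 1 `Nc1cc(N)c2nc(-c3ccccc3)c(Oc3ccc(Cl)c(Cl)c3)nc2c1`; in a functional assay on SR cells (Homo sapiens) for inhibition, read by sulforhodamine B assay, with a stated time of 48 h (on this read-out lower numbers stand for stronger inhibition of growth and higher numbers for weaker inhibition of growth), compound 1 gives 33900 nM
compound 2 `CCOC(=O)[C@H](CCC(=O)O)NC(=O)c1ccc(CNc2nc3cc(N)cc(N)c3nc2-c2ccccc2)cc1`; compound 2 gives 501 nM
compound 3 `COc1cc(CNc2nc3cc(N)cc(N)c3nc2-c2ccccc2)cc(OC)c1OC`; compound 3 gives 891 nM

Compound 1 stands at the highest number of the three, so it is the weakest inhibitor of growth here; its gaps to compound 3 and to compound 2 both lie beyond the scatter. Going by the values given here, compounds 2 and 3 carry a benzylamino linkage at the same position, whereas compound 1 carries an aryl ether, and no pair differing in a single place is available, so no measured step is known.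

Compound 4 `Nc1cc(N)c2nc(-c3ccccc3)c(Sc3ccc(F)cc3)nc2c1` is the next case, differing from compound 1 by (4-fluorophenyl)sulfanyl in place of 3,4-dichlorophenoxy on an aromatic carbon. The linkage type is kept closer to compound 1 than to compound 2 or compound 3, so the expected step from compound 1 to compound 4 is a 1.7-fold lower number from compound 1 to compound 4 (0.23 log units; within the scatter), small and likely within the scatter. Compound 4 is therefore estimated at 20000 nM, with a range from 5000 nM to 80000 nM.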

Compound 4, concentration for 50% growth inhibition: 35500 nM
Compound 4: the middle estimate sits 1.8-fold (0.25 log units) below what was measured; measured number inside the range.
By their numbers in this assay, from the lowest: compounds 2 and 3 (each within the scatter of the next); then compounds 1 and 4 (each within the scatter of the next).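

In this assay, going by these compounds alone, placing (4-fluorophenyl)sulfanyl where 3,4-dichlorophenoxy stood on this aromatic carbon gives a 1.0-fold higher number from compound 1 to compound 4 (0.02 log units; within the scatter) and is the only single-place step available. At this position, an aryl group joined through sulfur and one joined through oxygen therefore cannot be told apart on growth inhibition, even with two chlorine atoms leaving and one fluorine entering.

The step changes the linking atom and the ring halogens together, so the contribution of each remains unresolved. Also open, on these data alone, is what a morpholine or a carboxylic acid on a longer chain would give at this carbon in this assay on the shared core. No supporting measurement bears on why compound 1 and compound 4 fall so close together.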